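Series notes: amine substituent variation toward compound 4

The source may hold more compounds than are shown below. What is called first, only, known or untested is meant among the compounds shown, and "the series" means these compounds.

Measured in an assay on CHO cells for displacement of a labelled ligand from 5-hydroxytryptamine receptor 1B (Homo sapiens); a lower number here means a stronger inhibitor, a higher number a weaker inhibitor:
compound 1 `c1ccc2c(c1)CCC2NC1CCN(CCCc2c[nH]c3ccc(-n4cnnc4)cc23)CC1`: 280 nM
compound 2 `O=S(=O)(NCC1CCN(CCCc2c[nH]c3ccc(-n4cnnc4)cc23)CC1)c1ccccc1`: 60 nM
compound 3 `C[C@@H](NCC1CCN(CCCc2c[nH]c3ccc(-n4cnnc4)cc23)CC1)c1ccccc1`: 14 nM

Compound 3 gives the lowest number of the three in this assay; compound 2 lies nearest, a 4.3-fold lower number from compound 2 to compound 3 (0.63 log units; beyond the scatter), and compound 1 furthest, a 20-fold lower number from compound 1 to compound 3 (1.30 log units; beyond the scatter). Compound 4 `c1ccc(NCC2CCN(CCCc3c[nH]c4ccc(-n5cnnc5)cc34)CC2)nc1` is not yet measured. Its difference from compound 3: pyridin-2-yl in place of 1-phenylethyl on an amine nitrogen. The step that bears on it is the one at the same amine nitrogen, a 4.3-fold lower number from compound 2 to compound 3 (0.63 log units; beyond the scatter), a modest shift from the group on that nitrogen; a 4.7-fold lower number from compound 1 to compound 2 (0.67 log units; beyond the scatter) is of similar size at that position. Replacing 1-phenylethyl by pyridin-2-yl is therefore expected to move the number by a modest step, most likely upward, toward the value of compound 2. Compound 4 is estimated at 50 nM (range 15 nM to 170 nM), a step of a 3.6-fold higher number from compound 3 to compound 4 (0.55 log units; beyond the scatter).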

Compound 4, half-maximal inhibitory concentration: 3.3 nM
Compound 4: the middle estimate sits 15-fold (1.18 log units) above what was measured; measured number below the stated range.
By their numbers in this assay, from the lowest: compound 4; then compound 3; then compound 2; then compound 1.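

At the amine nitrogen, pyridin-2-yl gives a 4.2-fold lower number from compound 3 to compound 4 (0.63 log units; beyond the scatter) against 1-phenylethyl and an 18-fold lower number from compound 2 to compound 4 (1.26 log units; beyond the scatter) against phenylsulfonyl in this assay for this series. Within the data shown here, a group with fewer heavy atoms, a ring nitrogen and no defined stereocentre thus gives the lowest number so far, and an 85-fold lower number from compound 1 to compound 4 (1.93 log units; beyond the scatter) marks the full span from (2,3-dihydro-1H-inden-1-yl)amino to ((pyridin-2-yl)amino)methyl on a saturated ring carbon. No measurement at hand accounts for these steps.

Open, going by these compounds, is whether the ring nitrogen or the loss of the stereocentre carries the step. A plain phenyl or a pyridin-4-yl group on that amine nitrogen would separate the two.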